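A few compounds are considered here, and "the series" means these few. Any claim that something is new, unique, unknown or untested is made for them only; others in the source may bear on it.

Measured so far:
compound 1 `Cc1ccc(C(=O)Nc2cc(-c3ccccc3)nn2-c2ccccc2)cc1`: 40 nM
compound 2 `O=C(Nc1cc(-c2ccccc2)nn1-c1ccccc1)c1cccc(Cl)c1`: 200 nM
compound 3 `O=C(Nc1cc(-c2ccccc2)nn1-c1ccccc1)c1ccccn1`: 585 nM

In an assay on isolated protein with metabotropic glutamate receptor 5 (Rattus norvegicus) as the target (a higher number here means that more compound is needed for the effect, a lower number that less compound is needed), compound 3 stands highest of the three, beyond the scatter against both compound 2 and compound 1. The next step is 3-fluorophenyl in place of pyridin-2-yl on a carbonyl carbon, which gives compound 4 `O=C(Nc1cc(-c2ccccc2)nn1-c1ccccc1)c1cccc(F)c1`. The step that bears most directly on it is a 2.9-fold higher number from compound 2 to compound 3 (0.47 log units; beyond the scatter), where a 3-chlorophenyl group was exchanged for the pyridin-2-yl now being removed; the steps of a 5.0-fold higher number from compound 1 to compound 2 (0.70 log units; beyond the scatter) and a 15-fold higher number from compound 1 to compound 3 (1.17 log units; beyond the scatter) place the two phenyl-bearing amides below compound 3. Since 3-fluorophenyl resembles 3-chlorophenyl in compound 2, whose value is 200 nM, compound 4 is expected to show a 2.3-fold lower number from compound 3 to compound 4 (0.37 log units; beyond the scatter) in this assay. Compound 4 is therefore estimated at 250 nM, within 100 nM to 600 nM.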

Compound 4, half-maximal effective concentration: 65 nM
Beside the measured number, compound 4's estimate is 3.8-fold (0.59 log units) above it; measured number below the stated range.
By their numbers in this assay, from the lowest: compounds 1 and 4 (each within the scatter of the next); then compound 2; then compound 3.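

With fluoro in place of chloro on an aromatic carbon, the result is a 3.1-fold lower number from compound 2 to compound 4 (0.49 log units; beyond the scatter) in this assay, so the two halogens are not interchangeable at this position. 3-Fluorophenyl in place of pyridin-2-yl gives a 9.0-fold lower number from compound 3 to compound 4 (0.95 log units; beyond the scatter) and brings this series back to the range of the 4-methylphenyl amide, with a 1.6-fold higher number from compound 1 to compound 4 (0.21 log units; within the scatter) as the remaining difference. No measurement at hand accounts for these differences.

On these data alone, it remains open how a methoxy group, an amine or a carboxylic acid would fare on this ring, and whether 4-fluorophenyl would match 3-fluorophenyl. The rest of the core stays the same throughout, so what substituents there would do is also unknown.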